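The source may hold more compounds than are shown below. What is called first, only, known or untested is meant among the compounds shown, and "the series" means these compounds.

Working notes on the series. In a functional assay on NCI-H322M cells (Homo sapiens) for cytotoxicity, read by sulforhodamine B assay, with a stated time of 48 h (a lower number here means a stronger inhibitor of growth, a higher number a weaker inhibitor of growth), compound 1 `ClCc1ccc(Cn2cnc3c(Cl)ncnc32)cc1` gives 1820 nM. Compound 2 `ClCc1ccccc1Cn1cnc2c(Cl)nc(Cl)nc21` gives 1730 nM in this assay. Compound 3 `ClCc1ccc(Cn2cnc3nc(Cl)nc(Cl)c32)cc1` gives 670 nM in this assay. Compound 2 stands second highest of the three numbers; its gap to compound 1 is within the scatter, so no order between compound 1 and compound 2 can be read, while its gap to compound 3 lies beyond the scatter, compound 3 showing the lower number of the two. Within the data shown here, no pair of measured compounds differs in one place only, so no single-change step is available as a guide.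

Compound 4 `Nc1nc(Cl)c2ncn(Cc3ccccc3CCl)c2n1` is not yet measured in this assay. It differs from compound 2 in one place: amino in place of chloro on an aromatic carbon, on an aromatic carbon of a six-membered aromatic ring with two nitrogen, part of a fused system of two rings, between two ring nitrogen atoms, meta to a chloro group. Nothing in the measured set shows what this exchange does on this core. The expectation is therefore a step of modest size, if any, in this assay, estimated as a 1.4-fold higher number from compound 2 to compound 4 (0.16 log units; within the scatter); a weakening would not surprise, but a result within the scatter is about as likely. For compound 4 the estimate in this assay is 2500 nM, expected to fall between 900 nM and 7000 nM.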

Compound 4, concentration for 50% growth inhibition: 12300 nM
For compound 4 the middle estimate is 4.9-fold (0.69 log units) below the measured one, outside the stated range (above it).
By their numbers in this assay, from the lowest: compound 3; then compounds 2 and 1 (each within the scatter of the next); then compound 4.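

In this assay, among these compounds, the exchange of chloro for amino on the aromatic carbon between two ring nitrogen atoms gives a 7.1-fold higher number from compound 2 to compound 4 (0.85 log units; beyond the scatter) and so supplies the first single-change step, showing that this place is not indifferent to the group it carries and that the exchange weakens growth inhibition on this core. The exchange replaces one heavy atom with one heavy atom, so a step beyond the scatter arises here without any added ring or net charge, while the entering amino brings one hydrogen-bond donor and one hydrogen-bond acceptor that the chloro lacks. The data at hand give no measurement that explains the size or direction of this step.

From the compounds shown here alone, it remains open whether the step is particular to amino or would also appear with a methylamino, dimethylamino or methoxy group in the same place. Among the compounds shown here, also open is whether the same exchange would produce a step of similar size on the core of compound 3, since this single pair gives the only reading of the change.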